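Methoxy for fluoro on a selenocyanate carbamate

The source may hold more compounds than are shown below. What is called first, only, known or untested is meant among the compounds shown, and "the series" means these compounds.

Measured so far:
- compound 1, `N#C[Se]c1ccc(NC(=O)Oc2ccc(F)cc2)cc1`: 41900 nM
- compound 2, `O=C(Nc1ccc([Se][Se]c2ccc(NC(=O)OCc3ccc([N+](=O)[O-])cc3)cc2)cc1)OCc1ccc([N+](=O)[O-])cc1`: 36500 nM
- compound 3, `CCOC(=O)Nc1ccc([Se]C#N)cc1`: 39100 nM

The three compounds were tested in a functional assay on CCRF-CEM cells (Homo sapiens) for cytotoxicity, read by MTT assay, with a stated time of 72 h; on this read-out higher numbers stand for weaker inhibition of growth and lower numbers for stronger inhibition of growth. Compound 1 gives 41900 nM, compound 3 gives 39100 nM and compound 2 gives 36500 nM. On these numbers compound 1 stands at one end of a narrow band, but both compound 3 and compound 2 lie within the usual scatter of it, so the three cannot be told apart.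

Compound 4, `COc1ccc(OC(=O)Nc2ccc([Se]C#N)cc2)cc1`, has not yet been measured in this assay. It differs from compound 1 in one place: methoxy in place of fluoro on an aromatic carbon. Among the measured compounds shown here, no measured pair shows what such an exchange does here, and the three measured compounds, with their different carbamate groups and selenium units, all sit in the same band. The step from compound 1 to compound 4 is therefore expected to be small, a 1.0-fold lower number from compound 1 to compound 4 (0.02 log units; within the scatter), and not beyond the scatter in either direction. Compound 4 is estimated at 40000 nM, with a range from 20000 nM to 80000 nM.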

Compound 4, concentration for total growth inhibition: 41500 nM
The estimate for compound 4 lay 1.0-fold (0.02 log units) below the measured number, within the range that was stated.
By their numbers in this assay, from the lowest: compounds 2, 3, 4 and 1 (each within the scatter of the next).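

In this assay, methoxy in place of fluoro on an aromatic carbon, para to a large group, gives a 1.0-fold lower number from compound 1 to compound 4 (0.00 log units; within the scatter), so the two compounds cannot be told apart. The earlier compounds shown here differed from one another in more than one place and could say nothing about this position, whereas this pair shows that, on this read-out, the exchange of these two groups here leaves no difference that can be read. Nothing measured among these compounds bears on the reason for this result.

Only fluoro and methoxy are shown at this position, so it remains open whether an amine, a carboxylic acid or a longer chain such as butoxy there would also stay within the scatter of compound 1. From the compounds shown here alone, it is also open whether methoxy would read the same at another place on this ring.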